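Aryl swap on the ring amine nitrogen of the sulfonamide series

The source may report more compounds than this note shows. Statements on the series, on what has been measured and on what is new or still open speak of the compounds shown alone.

Compound 1 `CC1(C)[C@@H]2CC[C@@]1(CS(=O)(=O)N1CCN(c3ncccc3C(F)(F)F)CC1)C(=O)C2` and compound 2 `CC1(C)[C@@H]2CC[C@@]1(CS(=O)(=O)N1CCN(c3ccc(C#N)cn3)CC1)C(=O)C2` share one core and differ only in the aromatic group on the ring amine nitrogen. In a functional assay on CHO-K1 cells for antagonist activity at C-X-C chemokine receptor type 3 (Homo sapiens), read by FLIPR and calcium flux (on this read-out higher numbers stand for weaker inhibition and lower numbers for stronger inhibition), compound 1 returns only a limit of the assay, > 31600 nM. In this assay compound 2 likewise returns a limit, > 31600 nM. The step that the two limits leave unreadable from compound 1 to compound 2 is therefore not readable in size, because both values sit at the limit of > 31600 nM in this assay, at which 2 of the 2 values shown sit. Compound 2 thus stands at the limit, with no number of its own in this assay.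

Compound 3 `CC1(C)[C@@H]2CC[C@@]1(CS(=O)(=O)N1CCN(c3ccc(C(F)(F)F)cc3)CC1)C(=O)C2` carries the change (4-(trifluoromethyl)phenyl in place of 5-cyanopyridin-2-yl on an amine nitrogen in a ring). For the measured compounds named here, no measured step bears on this change; the one step measured so far gives no readable size. Compound 3 is therefore expected to give 31600 nM in this assay, within 5000 nM to 100000 nM. The step of a number no higher from compound 2 to compound 3 (the limit leaves the size open) is expected to be none that could be read against the limit of compound 2.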

Compound 3, half-maximal inhibitory concentration: > 31600 nM
Compound 3 gave a limit, no number (the forecaster's own chance of this, stated with the estimate: 70%); the middle value lies on the limit itself.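

Compound 3 gives no readable step against compound 1 or compound 2, since all three values are limits and not numbers: the limit of > 31600 nM in this assay, at which 3 of the 3 values shown sit.

The compounds shown leave open how these three aromatic groups on the ring amine nitrogen rank in this assay and whether any group there gives a measurable inhibition.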